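Changing the sulfur-linked ring in a flat series

The compounds below may be only part of what the source reports. "The series", "measured", "known", "first", "only" and "open" are said of these compounds alone.

Measured so far in a functional assay on LNCaP cells (Homo sapiens) for antiproliferative activity, read by propidium iodide staining, with a stated time of 96 h; on this read-out higher numbers stand for weaker inhibition and lower numbers for stronger inhibition:
Compound 1 `CC(O)(CSc1cccc(S(F)(F)(F)(F)F)c1)C(=O)Nc1ccc(C#N)cc1C(F)(F)F`: 17600 nM
Compound 2 `CC(O)(CSc1ccc(S(F)(F)(F)(F)F)cc1)C(=O)Nc1ccc(S(F)(F)(F)(F)F)cc1`: 18300 nM
Compound 3 `CC(O)(CSc1ccc(F)cc1)C(=O)Nc1ccc(S(F)(F)(F)(F)F)cc1`: 12500 nM

Compound 3, at 12500 nM, cannot be told apart from the other two compounds, since its value lies within the usual scatter of both. Compound 4 `CC(O)(CSc1ccc(C(F)(F)F)cn1)C(=O)Nc1ccc(S(F)(F)(F)(F)F)cc1` differs from compound 3 only in the aromatic group on the sulfur: 5-(trifluoromethyl)pyridin-2-yl in place of 4-fluorophenyl on a sulfur. In words, this is 5-(trifluoromethyl)pyridin-2-yl in place of 4-fluorophenyl on a sulfur.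

One measured step also exchanges a group on the aromatic ring carried by that sulfur: a 1.5-fold lower number from compound 2 to compound 3 (0.17 log units; within the scatter). That step is small and stays within the scatter. Within the data shown here, no measured compound has a ring nitrogen in this part of the molecule, so that feature remains untested. With so little evidence, no step beyond the scatter is expected in this assay. The estimated step is a 1.1-fold higher number from compound 3 to compound 4 (0.05 log units; within the scatter). Compound 4 is estimated at 14000 nM, with an expected range of 7000 nM to 28000 nM.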

Compound 4, half-maximal inhibitory concentration: 12300 nM
The estimate for compound 4 lay 1.1-fold (0.06 log units) above the measured number, within the range that was stated.
By their numbers in this assay, from the lowest: compounds 4, 3, 1 and 2 (each within the scatter of the next).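

In this assay, 5-(trifluoromethyl)pyridin-2-yl in place of 4-fluorophenyl on the sulfur gives a 1.0-fold lower number from compound 3 to compound 4 (0.01 log units; within the scatter) and the two compounds cannot be told apart. Among the compounds shown, only compound 4 carries a ring nitrogen and a hydrogen-bond acceptor in this group, so this position accepts a larger aromatic group containing nitrogen with no step beyond the scatter. No measurement is available to explain this flat result.

As far as these compounds go, the ring nitrogen and the trifluoromethyl group enter together in this one step, so the contribution of each alone stays unknown. Also open, from the compounds shown here alone, is whether an amine or a carboxylic acid on this ring, or a saturated ring or a plain alkyl chain on the sulfur in place of the aromatic ring, would give a step beyond the scatter.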